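A few compounds are considered here, and "the series" means these few. Any claim that something is new, unique, unknown or untested is made for them only; others in the source may bear on it.

Measured compounds and their values:

Compound 1: `COc1cccc2sc(NC(=O)c3ccc(C(F)(F)F)cc3)nc12` — > 10 ug/mL
Compound 2: `COc1cccc2sc(NC(=O)c3ccc([N+](=O)[O-])cc3)nc12` — > 10 ug/mL
Compound 3: `Cc1cc(C)c2sc(NC(=O)c3ccc([N+](=O)[O-])cc3)nc2c1` — 1.74 ug/mL

Three compounds were tested in a functional assay on SK-HEP1 cells (Homo sapiens) for antiproliferative activity, read by sulforhodamine B assay; a higher number here means a weaker inhibitor of growth, a lower number a stronger inhibitor of growth. Compound 1 returned only a limit of the assay, > 10 ug/mL, and no number. Compound 2 likewise returned only a limit, > 10 ug/mL. Within the data shown here, compound 3 is the one compound with a number, giving 1.74 ug/mL in this assay.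

Compounds 2 and 1 share a core and differ by trifluoromethyl in place of nitro on an aromatic carbon. The measured step is a step that the two limits leave unreadable from compound 2 to compound 1, and this rests on (the limit of > 10 ug/mL in this assay, at which 2 of the 3 values shown sit), where both values sit. How the core of compound 3 differs from that of compound 2 is not broken down here.

Compound 4, `Cc1cc(C)c2sc(NC(=O)c3ccc(C(F)(F)F)cc3)nc2c1`, has not yet been measured in this assay. It carries the core of compound 3 and differs from it by trifluoromethyl in place of nitro on an aromatic carbon. Among the measured compounds shown here, the place lines of the two changes are the same word for word, so this is the same change as the one from compound 2 to compound 1. Since that earlier step is not readable, the size of a 1.4-fold higher number from compound 3 to compound 4 (0.16 log units; within the scatter) is expected with little confidence, and it rests only on the value of compound 3, 1.74 ug/mL, as a starting point. Compound 4 is therefore estimated at 2.5 ug/mL in this assay, with a range expected from 0.8 ug/mL to 10 ug/mL.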

Compound 4, concentration for 50% growth inhibition: 1.36 ug/mL
For compound 4 the middle estimate is 1.8-fold (0.26 log units) above the measured one; the range from low to high includes it.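

In this assay, replacing the nitro group with trifluoromethyl, para to a large group, gives a 1.3-fold lower number from compound 3 to compound 4 (0.11 log units; within the scatter), so on the core of compound 3 the two groups cannot be told apart in this read-out. Among these compounds, the same change on the other core cannot be read, because compound 2 and compound 1 each stand only at a limit of the assay, not at a number: the limit of > 10 ug/mL in this assay, at which 2 of the 4 values shown sit. The series therefore shows that the change leaves the read-out within the scatter on one core, but it does not show that the change carries over from one core to the other, since only one of the two steps has a readable size.

The compounds shown carry only nitro or trifluoromethyl at this place, so it remains open what an amine, a carboxylic acid or a longer chain such as butyl would do there on either core. Among the compounds shown here, it also remains open how the two cores compare in their own right, as no single-place step connects them.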